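Nitro for Methyl on a Curcumin-like Benzimidazole Chalcone

The source may report more compounds than this note shows. Statements on the series, on what has been measured and on what is new or still open speak of the compounds shown alone.

Measured compounds:
Compound 1, `COc1ccc(/C=C/C(=O)/C=C/c2nc3cc(C)ccc3n2C)cc1O` — 4800 nM
Compound 2, `COc1ccc(/C=C/C(=O)/C=C/c2nc3c(C)c(C)ccc3n2C)cc1O` — 4800 nM

In a functional assay on SH-SY5Y cells (Homo sapiens) for cytotoxicity, read by MTT assay, with a stated time of 48 h (a higher number here means a weaker inhibitor, a lower number a stronger inhibitor), compound 1 gives 4800 nM. Compound 2, which carries one more methyl on an aromatic carbon of the shared core, gives 4800 nM in the same assay, and the pair shows no change at the digits printed from compound 1 to compound 2 (within the scatter). Compound 1 therefore stands level with compound 2 on the numbers available, with nothing to separate them.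

The unmeasured compound 3, `COc1ccc(/C=C/C(=O)/C=C/c2nc3cc([N+](=O)[O-])ccc3n2C)cc1O`, differs from compound 1 by nitro in place of methyl on an aromatic carbon. For the measured compounds named here, the only measured step, that from compound 1 to compound 2, concerns a methyl added to the shared core and shows no change; no measured step exchanges a methyl for a nitro at this position, so that step bears on the present change only loosely, as a sign that substitution on this ring has so far left the read-out untouched.

On that basis the step from compound 1 to compound 3 in this assay is expected to be no change at the digits printed from compound 1 to compound 3 (within the scatter), no change beyond the scatter, though with a wider uncertainty than the methyl step would suggest. Compound 3 is accordingly estimated at 4800 nM, with a range from 1800 nM to 13000 nM.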

Compound 3, half-maximal inhibitory concentration: 8100 nM
Estimate against measurement, compound 3: 1.7-fold (0.23 log units) below; measured number inside the range.
By their numbers in this assay, from the lowest: compounds 1, 2 and 3 (each within the scatter of the next).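

In this assay, exchanging methyl for nitro on an aromatic carbon of the shared core gives a 1.7-fold higher number from compound 1 to compound 3 (0.23 log units; within the scatter) and so stays within the scatter, even though this change replaces the group on that carbon rather than adding one elsewhere on the ring. The earlier pair showed only that one more methyl could be added to the core without a change at the digits printed; this step shows that the methyl of compound 1 is not needed for the read-out to stay within the scatter, even with a nitro group bringing hydrogen-bond acceptors that methyl lacks. No supporting measurement accounts for the two groups reading alike in this cell assay.

It remains open whether an amine, a carboxylic acid or a longer chain on this same carbon would also stay within the scatter, as methyl and nitro are the only groups shown there. Also open, on these data alone, is whether a methoxy group or a chlorine atom at this place would leave the read-out as undisturbed as the nitro group does.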